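Swapping the Aryl Group on the Amine Nitrogen

This account rests on a few compounds, and the source may have more. Where it says the series, first, only, none or still open, it means among the compounds named here.

Three compounds share one core and differ only in the aryl group on an amine nitrogen. Compound 1 `Fc1cccc(NCn2nc(-c3ccc4c(c3)OCCO4)oc2=S)c1` gives 6620 nM in a functional assay, with a stated time of 6 min; a lower number here means a stronger inhibitor, a higher number a weaker inhibitor. Compound 2 `S=c1oc(-c2ccc3c(c2)OCCO3)nn1CNc1cc(Cl)ccc1Cl` gives 5420 nM in this assay, and compound 3 `S=c1oc(-c2ccc3c(c2)OCCO3)nn1CNc1ccc(Cl)c(Cl)c1` gives 6840 nM. Compound 3 shows the highest of the three numbers, yet every step among them lies within the scatter: a 1.2-fold lower number from compound 1 to compound 2 (0.09 log units; within the scatter), a 1.0-fold higher number from compound 1 to compound 3 (0.01 log units; within the scatter) and a 1.3-fold higher number from compound 2 to compound 3 (0.10 log units; within the scatter). Compound 4 `O=[N+]([O-])c1ccccc1NCn1nc(-c2ccc3c(c2)OCCO3)oc1=S` arises from compound 3 by 2-nitrophenyl in place of 3,4-dichlorophenyl on an amine nitrogen. The measured steps each exchanged one aryl group for another at this position and none moved the number beyond the scatter, so the change from compound 3 to compound 4 is expected to be small, a 1.1-fold lower number from compound 3 to compound 4 (0.02 log units; within the scatter), with no clear direction. Compound 4 is therefore estimated at 6500 nM in this assay, expected to fall between 2500 nM and 17000 nM.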

Compound 4, half-maximal inhibitory concentration: 10900 nM
The estimate for compound 4 lay 1.7-fold (0.22 log units) below the measured number; measured number inside the range.
By their numbers in this assay, from the lowest: compounds 2, 1, 3 and 4 (each within the scatter of the next).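

The 2-nitrophenyl group carries hydrogen-bond acceptors that 3,4-dichlorophenyl lacks, yet this assay shows a 1.6-fold higher number from compound 3 to compound 4 (0.20 log units; within the scatter) and a 1.6-fold higher number from compound 1 to compound 4 (0.22 log units; within the scatter) and a 2.0-fold higher number from compound 2 to compound 4 (0.30 log units; within the scatter) as its steps. Going by these compounds alone, this position on the amine nitrogen has now taken an aryl group without halogen, and still no step has left the scatter. As far as these compounds go, what a carboxylic acid or an amine on this ring would do stays open, as does a longer chain in place of the aryl group. Nothing available explains why these numbers sit where they do.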